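The source may report more compounds than this note shows. Statements on the series, on what has been measured and on what is new or still open speak of the compounds shown alone.

Compound 1 `Cc1ccc(S/C(=C/c2c[nH]c3ccccc23)C(=O)c2ccc(Br)cc2)cc1` belongs to a pair of closely related molecules tested in a functional assay on DU-145 cells (Homo sapiens) for inhibition, read by trypan blue exclusion, with a stated time of 96 h; on this read-out higher numbers stand for weaker inhibition of growth and lower numbers for stronger inhibition of growth. In this assay compound 1 gives 10000 nM. Its only measured partner, compound 2 `Cc1ccc(S(=O)(=O)/C(=C/c2c[nH]c3ccccc23)C(=O)c2ccc(Br)cc2)cc1`, differs in a single place, and in this assay compound 2 gives 10000 nM. The step of no change at the digits printed from compound 1 to compound 2 (within the scatter) lies within the scatter, so the two values are level and this small set shows no spread at all.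

Compound 3 `Cc1ccc(S/C(=C/c2ccc(C)s2)C(=O)c2ccc(Br)cc2)cc1` has not yet been measured. It differs from compound 1 in one place: 5-methylthiophen-2-yl in place of 1H-indol-3-yl on a double-bonded chain carbon bound to a double-bonded chain carbon. Going by the values given here, the single measured step, from compound 1 to compound 2, alters the sulfur-bearing group and leaves the 1H-indol-3-yl group untouched, so it offers no guide to swapping that ring for 5-methylthiophen-2-yl. Among the compounds with values here, with no step that bears on this change, the expectation for the step of no change at the digits printed from compound 1 to compound 3 (within the scatter) is no change beyond the scatter, while the uncertainty is wide in both directions. Compound 3 is therefore expected to give 10000 nM in this assay, with a range from 2000 nM to 30000 nM.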

Compound 3, concentration for 50% growth inhibition: > 100000 nM
Compound 3: a limit, no number (the forecaster's own chance of this, stated with the estimate: 50%); middle value at least 10-fold (1.00 log units) away from the limit.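

Replacing 1H-indol-3-yl with 5-methylthiophen-2-yl on a double-bonded chain carbon bound to a double-bonded chain carbon gives an at least 10-fold higher number from compound 1 to compound 3 (1.00 log units; beyond the scatter), which means weaker inhibition of growth in this assay. Going by these compounds alone, the earlier change at the sulfur-bearing group gave no change at the digits printed from compound 1 to compound 2 (within the scatter), so this ring position is the first place in the set where a change separates two compounds. The reading for compound 3 is a limit of the assay and not a number, so the step has no exact size: the limit of > 100000 nM in this assay, at which 1 of the 3 values shown sits.

This swap changes several things at once: the six-membered aromatic ring and the hydrogen-bond donor leave, while a sulfur-containing ring with a methyl group enters, and the compounds shown cannot tell which of these differences matters. As far as these compounds go, a 1-methylindol-3-yl group would test the role of the donor on the original ring system, a plain thiophen-2-yl group would test the role of the methyl, and it also remains open how the (4-methylphenyl)sulfonyl group of compound 2 would behave alongside 5-methylthiophen-2-yl.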